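Ethoxy for trifluoromethyl next to the ring nitrogen

The compounds below may be only part of what the source reports. "The series", "measured", "known", "first", "only" and "open" are said of these compounds alone.

Working notes on three measured amides and one open analogue. In an assay on CHO cells for positive allosteric modulation of Cystic fibrosis transmembrane conductance regulator variant F508del (Homo sapiens), using a membrane potential dye, with a stated time of 30 min, in the presence of a further agent that is not named here (on this read-out lower numbers stand for an effect already at smaller amounts and higher numbers for an effect only at larger amounts of compound), compound 1 `CC(C)(O)CNC(=O)c1nc(Br)c(C(F)(F)F)cc1N` gives 77 nM, compound 2 `CC(O)(CNC(=O)c1ncc(C(F)(F)F)cc1N)C(F)(F)F` gives 229 nM, and compound 3 `C[C@](O)(CNC(=O)c1nc(C(F)(F)F)c(C(F)(F)F)cc1N)C(F)(F)F` gives 9 nM. Compound 3 stands lowest of the three numbers in this assay; the gap to compound 1 and the wider gap to compound 2 both lie beyond the usual scatter, so compound 3 is the most potent of the set on this read-out. For the measured compounds named here, compound 2 and compound 3 differ in more than one place, so their two values show only that the pair with the trifluoromethyl on the core and the defined stereocentre sits well below the other.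

Compound 4 `CCOc1nc(C(=O)NC[C@](C)(O)C(F)(F)F)c(N)cc1C(F)(F)F` carries one change against compound 3: ethoxy in place of trifluoromethyl on an aromatic carbon. Going by the values given here, no measured pair isolates this exchange, so the expectation rests on the position itself, where compound 1 with bromine gives 77 nM and compound 3 with trifluoromethyl gives 9 nM. A moderate rise in the number, toward weaker potency, is expected for this assay, with the step from compound 3 to compound 4 estimated at a 2.8-fold higher number from compound 3 to compound 4 (0.44 log units; beyond the scatter). Compound 4 is therefore expected to give about 25 nM in this assay, within a range of 6 nM to 100 nM.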

Compound 4, half-maximal effective concentration in the Cystic fibrosis transmembrane conductance regulator assay: 15 nM
Estimate against measurement, compound 4: 1.7-fold (0.22 log units) above; the range from low to high includes it.
By their numbers in the Cystic fibrosis transmembrane conductance regulator assay, from the lowest: compounds 3 and 4 (each within the scatter of the next); then compound 1; then compound 2.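

For the compounds shown here, in the Cystic fibrosis transmembrane conductance regulator assay, ethoxy in place of trifluoromethyl next to the ring nitrogen gives a 1.7-fold higher number from compound 3 to compound 4 (0.22 log units; within the scatter) and is the first exchange at this position that can be read on its own, since compound 1 and compound 2 each differ from compound 3 in more than one place. In a physicochemical assay for solubility, at pH 6.8 (on this read-out lower numbers stand for lower solubility and higher numbers for higher solubility), the same exchange gives a 1.4-fold lower number from compound 3 to compound 4 (0.14 log units; within the scatter) and so compound 3 at 82 ug/mL and compound 4 at 60 ug/mL also stay within the usual scatter of each other. Nothing among the data shown accounts for either result through a property of the two groups.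

Open, as far as these compounds go, is whether this position holds the same range with a longer chain such as propoxy, or with an amine such as dimethylamino, since the one-place comparison here covers only trifluoromethyl and ethoxy. Bromine in compound 1 and the ring hydrogen in compound 2 also remain unplaced against ethoxy, as both compounds differ from compound 4 in more than one place.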